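The compounds below may be only part of what the source reports. "The series", "measured", "known", "first", "only" and "open" are said of these compounds alone.

Compound 1 `N#Cc1ccc2c(Oc3ccccc3OCCn3ccc(=O)[nH]c3=O)cccc2c1`: in an ADME assay on MT2 cells (Homo sapiens) for cytotoxicity, read by MTT assay (a lower number here means that less compound is tolerated, a higher number that more compound is tolerated), compound 1 gives > 100000 nM, a limit of the assay.
Compound 2 `N#Cc1ccc2c(Oc3ccc(Cl)cc3OCCn3ccc(=O)[nH]c3=O)cccc2c1`: compound 2 gives > 100000 nM, a limit.
Compound 3 `N#Cc1ccc2c(Oc3ccc(F)cc3OCCn3ccc(=O)[nH]c3=O)cccc2c1`: compound 3 gives > 100000 nM, a limit.

Compound 2 thus stands only at a limit, and the two other values shown are limits as well; all three sit at the limit of > 100000 nM in this assay, at which 3 of the 3 values shown sit. Compound 4 `N#Cc1ccc2c(Oc3ccc(Cl)cc3OCCn3ccc(=O)[nH]c3=O)cc(F)cc2c1` differs from compound 2 by fluoro in place of hydrogen on an aromatic carbon. The measured steps that bear on this are a step that the two limits leave unreadable from compound 1 to compound 2, a step that the two limits leave unreadable from compound 1 to compound 3 and a step that the two limits leave unreadable from compound 2 to compound 3; none of them has a readable size, so no direction can be taken from them, and no step beyond the scatter is expected. For compound 4 the estimate in this assay is 150000 nM, with a range from 80000 nM to 300000 nM. The expected step is a step that the limit leaves unreadable from compound 2 to compound 4, most likely reported again only as a limit.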

Compound 4, half-maximal cytotoxic concentration: 18000 nM
For compound 4 the middle estimate is 8.3-fold (0.92 log units) above the measured one; the whole stated range lies above it.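

Within the data shown here, the fluoro that compound 4 carries on the fused system gives the first readable step in this assay: an at least 5.5-fold lower number from compound 2 to compound 4 (0.74 log units; beyond the scatter). The steps among compound 1, compound 2 and compound 3 cannot be read, so this position alone moves a value off the limit. Compound 4 is the only compound shown with a value that is not a limit: the limit of > 100000 nM in this assay, at which 3 of the 4 values shown sit.

Open, from the compounds shown here alone, is whether a methoxy group or an amine at this position would give a similar step. Also open, going by these compounds, is whether fluoro here lowers the number without the chloro of compound 2.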